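This account rests on a few compounds, and the source may have more. Where it says the series, first, only, none or still open, it means among the compounds named here.

In a functional assay on KB-VIN10 cells (Homo sapiens) for inhibition, with a stated time of 72 h (a lower number here means a stronger inhibitor, a higher number a weaker inhibitor), the three measured compounds are:

Compound 1 `COc1ccc(S(=O)(=O)N2CCc3cccc(-c4ccc(N)cc4)c32)cc1`: 262 nM
Compound 2 `COc1ccc(S(=O)(=O)N2CCc3cccc(-c4ccc(F)nc4)c32)cc1`: 151 nM
Compound 3 `COc1ccc(S(=O)(=O)N2CCc3cccc(-c4ccco4)c32)cc1`: 79.2 nM

Compound 3 sits at the low end of these three numbers, but only one gap goes beyond the scatter: a 3.3-fold lower number from compound 1 to compound 3 (0.52 log units; beyond the scatter). The other two steps stay within it: a 1.9-fold lower number from compound 2 to compound 3 (0.28 log units; within the scatter), and a 1.7-fold lower number from compound 1 to compound 2 (0.24 log units; within the scatter).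

The next compound is compound 4 `COc1ccc(S(=O)(=O)N2CCc3cccc(-c4ccc([N+](=O)[O-])cc4)c32)cc1`. The change is 4-nitrophenyl in place of furan-2-yl on an aromatic carbon; in words, 4-nitrophenyl in place of furan-2-yl on an aromatic carbon.

Among the measured compounds shown here, no measured compound carries 4-nitrophenyl, so the closest guide is compound 1, whose 4-aminophenyl is also a substituted phenyl. Its step to the furan-2-yl compound was modest: a 3.3-fold lower number from compound 1 to compound 3 (0.52 log units; beyond the scatter). Compound 2 has a six-membered aromatic ring in the same place, and its step to the furan-2-yl compound was within the scatter: a 1.9-fold lower number from compound 2 to compound 3 (0.28 log units; within the scatter). Together these suggest that replacing furan-2-yl with a six-membered aromatic ring may raise the number somewhat, though three compounds are thin support. In this assay, a small to modest rise is therefore expected: a 2.4-fold higher number from compound 3 to compound 4 (0.38 log units; beyond the scatter). The estimated value for compound 4 is 190 nM, with an expected range from 60 nM to 600 nM.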

Compound 4, half-maximal inhibitory concentration: 51.3 nM
Beside the measured number, compound 4's estimate is 3.7-fold (0.57 log units) above it; the measured number lies below the stated range.
By their numbers in this assay, from the lowest: compounds 4, 3, 2 and 1 (each within the scatter of the next, the first and the last beyond it).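

In this assay, furan-2-yl is not required at this aromatic carbon: putting 4-nitrophenyl there gives a 1.5-fold lower number from compound 3 to compound 4 (0.19 log units; within the scatter) and leaves the two compounds indistinguishable, so a six-membered aromatic ring of carbon only can serve as well as the five-membered ring. The group carried by that phenyl ring also matters, as nitro in place of amino gives a 5.1-fold lower number from compound 1 to compound 4 (0.71 log units; beyond the scatter) in the largest step among these four compounds. The six-membered rings tested here do not all give the same result either, since 4-nitrophenyl in place of 6-fluoropyridin-3-yl gives a 2.9-fold lower number from compound 2 to compound 4 (0.47 log units; beyond the scatter) as a modest step beyond the usual scatter.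

Nothing available explains why these groups give different numbers. Also open, going by these compounds, is how a phenyl ring carrying a nitrile, a methoxy group or a carboxylic acid in place of the nitro group would compare, which would show whether the step from amino to nitro belongs to a wider series or stands alone.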